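Adding a Third Methoxy Group to an Aminophenyl Pyrazoline

This account rests on a few compounds, and the source may have more. Where it says the series, first, only, none or still open, it means among the compounds named here.

Compound 1 `COc1ccc(N)c(C2=NN(C(=O)CCc3ccccc3)CC2)c1` and compound 2 `COc1cc(N)c(C2=NN(C(=O)CCc3ccccc3)CC2)cc1OC` share a core and differ in one spot. In an assay on isolated protein for inhibition of Nitric oxide synthase, inducible (Homo sapiens), with a stated time of 30 min, tested at 1 mM (on this read-out lower numbers stand for less inhibition and higher numbers for more inhibition at the one concentration tested (going by the name of the read-out)), compound 1 gives 21.2%, and compound 2 gives 23.7%. The change from a number 2.5 percentage points higher from compound 1 to compound 2 (within the scatter) came from a methoxy in place of hydrogen on an aromatic carbon. Compound 2 therefore holds the higher of the two numbers shown, but its gap to compound 1 lies within the scatter, so the two cannot be told apart.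

Compound 3 `COc1cc(N)c(C2=NN(C(=O)CCc3ccccc3)CC2)c(OC)c1OC` goes one step further: methoxy in place of hydrogen on an aromatic carbon. Within the data shown here, the only measured step of the same kind is the one from compound 1 to compound 2, which stayed within the scatter. On that basis the step of a number 1.3 percentage points higher from compound 2 to compound 3 (within the scatter) is expected to stay within the scatter as well. Compound 3 is accordingly estimated to give 25%, with a likely range from 10% to 40%.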

Compound 3, a percentage reported as inhibition, at one concentration (the size of the read-out at that concentration, not a potency): 18.3%
The estimate for compound 3 lay 6.7 percentage points above the measured number; measured number inside the range.
By their numbers in this assay, from the lowest: compounds 3, 1 and 2 (each within the scatter of the next).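

On this carbon, ortho to a large group and ortho to a methoxy group, methoxy in place of hydrogen gives a number 5.4 percentage points lower from compound 2 to compound 3 (within the scatter) in this assay. This is a second site on the same aromatic ring where the swap leaves the read-out within the scatter, so neither of the two measured methoxy steps can be told apart from no change, and compound 2 and compound 3 count as equal here. Nothing available explains this outcome or tells what the added methoxy does at this carbon.

On these data alone, whether a larger group such as ethoxy, or a single chlorine atom, would move the number beyond the scatter on this carbon stays open. So does the effect of replacing the amino group with a hydroxy group on the same core.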